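Swapping Chloro for Methyl on a Weakly Cytotoxic Scaffold

The source may report more compounds than this note shows. Statements on the series, on what has been measured and on what is new or still open speak of the compounds shown alone.

Within the data shown here, in a functional assay on PC-3 cells (Homo sapiens) for cytotoxicity, read by MTT assay, with a stated time of 72 h (on this read-out lower numbers stand for stronger inhibition and higher numbers for weaker inhibition), compound 1 `Cc1cc(Nc2ccc(Cl)cc2)nc(SCc2nc3ccccc3[nH]2)n1` gives 36000 nM, one of only two plain numbers among the three compounds measured. Compound 3 `Cc1cc(Nc2ccc(Br)cc2)nc(SCc2nc3ccccc3[nH]2)n1` gives 37100 nM, and the step of a 1.0-fold higher number from compound 1 to compound 3 (0.01 log units; within the scatter) is within the scatter. Compound 2 `Cc1cc(N2CCNCC2)nc(SCc2nc3ccccc3[nH]2)n1` returns only a limit of this assay, > 100000 nM. The step of an at least 2.7-fold higher number from compound 1 to compound 2 (0.44 log units; beyond the scatter) therefore counts as at least modest.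

Compound 4 `Cc1ccc(Nc2cc(C)nc(SCc3nc4ccccc4[nH]3)n2)cc1` differs from compound 1 by methyl in place of chloro on an aromatic carbon. Among the measured compounds shown here, the one measured step that bears on this, an exchange of a single ring substituent at the same place, is a 1.0-fold higher number from compound 1 to compound 3 (0.01 log units; within the scatter), within the scatter. Compound 4 is therefore expected to show no step beyond the scatter, a 1.1-fold higher number from compound 1 to compound 4 (0.05 log units; within the scatter). Compound 4 is estimated at 40000 nM, with a range from 15000 nM to 100000 nM.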

Compound 4, half-maximal inhibitory concentration: 56000 nM
For compound 4 the middle estimate is 1.4-fold (0.15 log units) below the measured one; the measured number falls inside the stated range.
By their numbers in this assay, from the lowest: compounds 1, 3 and 4 (each within the scatter of the next). At a limit, above all of these: compound 2.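

In this assay the step of a 1.6-fold higher number from compound 1 to compound 4 (0.19 log units; within the scatter) and the step of a 1.5-fold higher number from compound 3 to compound 4 (0.18 log units; within the scatter) both stay small, so on this ring a methyl reads like chloro and bromo, and three different groups at this place show no change beyond the scatter. The exchange of piperazin-1-yl gives an at least 1.7-fold lower number from compound 2 to compound 4 (0.25 log units; that floor lies within the scatter) as its step, which is only a floor set by a limit: the limit of > 100000 nM in this assay, at which 1 of the 4 values shown sits.

As far as these compounds go, whether an amine or a carboxylic acid in place of the chloro of the 4-chlorophenyl group would move the number beyond the scatter stays open, and so does the reading for a longer chain there.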